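A few compounds are considered here, and "the series" means these few. Any claim that something is new, unique, unknown or untested is made for them only; others in the source may bear on it.

In an ADME assay on MT4 cells (Homo sapiens) for cytotoxicity, read by MTT assay, with a stated time of 4 days (a higher number here means that more compound is tolerated, a lower number that less compound is tolerated), two compounds have been measured so far. Compound 1 `CCOC(=O)c1cnc(N2CCN(Cc3cccc(F)c3)CC2)nc1Oc1c(C)cc(-c2ccc(C#N)cc2)cc1C` gives > 125000 nM, which is a limit of the assay and not a number. Compound 2 `CCOC(=O)c1cnc(N2CCN(Cc3cccc([N+](=O)[O-])c3)CC2)nc1Oc1c(C)cc(-c2ccc(C#N)cc2)cc1C` gives > 125000 nM, which is likewise a limit and not a number. Compound 2 therefore has no exact place on the scale, and it shares with compound 1 (the limit of > 125000 nM in this assay, at which 2 of the 2 values shown sit).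

Compound 3 `CCOC(=O)c1cnc(N2CCN(Cc3cc(F)cc(F)c3)CC2)nc1Oc1c(C)cc(-c2ccc(C#N)cc2)cc1C` differs from compound 2 at a single place: 3,5-difluorophenyl in place of 3-nitrophenyl on a saturated chain carbon bound to an amine nitrogen in a ring. A 3,5-difluorophenyl stands in place of the 3-nitrophenyl on a saturated chain carbon bound to an amine nitrogen in a ring.

For the measured compounds named here, the one measured step that bears on this change is a step that the two limits leave unreadable from compound 1 to compound 2, and it offers no size to carry over. No step beyond the scatter is therefore expected in this assay, and no direction can be named. The expected outcome is a number no higher from compound 2 to compound 3 (the limit leaves the size open). Compound 3 is estimated at about 125000 nM, with an expected range of 60000 nM to 250000 nM, and the assay may well report only a limit again.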

Compound 3, half-maximal cytotoxic concentration: > 125000 nM
Compound 3: only a limit was reported; the forecaster's own chance of this, stated with the estimate: 75%; the middle value lies on the limit itself.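

Compound 3, like compound 1 and compound 2, is reported only as a limit in this assay, so no step among the three can be read: the limit of > 125000 nM in this assay, at which 3 of the 3 values shown sit.

The compounds shown leave open what number any of the three would give, and whether the changes on the benzyl group shift that number at all.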